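Replacing the nitro group of compound 1: working notes

A few compounds are considered here, and "the series" means these few. Any claim that something is new, unique, unknown or untested is made for them only; others in the source may bear on it.

Measured so far:
compound 1 `Cc1cc(NC(=O)Cn2cc(-c3ccc([N+](=O)[O-])cc3)nn2)no1` — 1220 nM
compound 2 `Cc1csc(NC(=O)Cn2cc(-c3ccc([N+](=O)[O-])cc3)nn2)n1` — 190 nM

In a functional assay on BMDM cells (Mus musculus, strain C57BL/6) for inhibition, with a stated time of 2 days (on this read-out lower numbers stand for stronger inhibition and higher numbers for weaker inhibition), compound 1 gives 1220 nM, the highest of the two numbers seen so far. Compound 2 gives 190 nM in this assay. Among the compounds with values here, the only measured step, a 6.4-fold lower number from compound 1 to compound 2 (0.81 log units; beyond the scatter), comes from 4-methyl-1,3-thiazol-2-yl in place of 5-methyl-1,2-oxazol-3-yl on the amide-type nitrogen, and it lies beyond the scatter.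

Compound 3 `C#Cc1ccc(-c2cn(CC(=O)Nc3cc(C)on3)nn2)cc1` keeps the amide side of compound 1 and differs from it at the other end: ethynyl in place of nitro on an aromatic carbon. Within the data shown here, no measured step touches this position; the one step in hand concerns a different part of the shared core, so it gives no direction for this change. With no basis for movement either way, no step beyond the scatter is expected, and the range is kept wide.

Compound 3 is therefore expected to give 1400 nM in this assay, within 400 nM to 5000 nM. The step of a 1.1-fold higher number from compound 1 to compound 3 (0.06 log units; within the scatter) is expected to stay within the scatter.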

Compound 3, half-maximal inhibitory concentration: > 30000 nM
Compound 3: no number, only a limit; the forecaster's own chance of this, stated with the estimate: 10%; middle value at least 21-fold (1.33 log units) away from the limit.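

Ethynyl in place of nitro on an aromatic carbon gives an at least 24-fold higher number from compound 1 to compound 3 (1.39 log units; beyond the scatter), so this position, which no earlier step touched, is far from indifferent on the core of compound 1. From the compounds shown here alone, compound 3 has no number in this assay, only a limit, so the true size of the step stays unknown: the limit of > 30000 nM in this assay, at which 1 of the 3 values shown sits. Nitro counts 2 hydrogen-bond acceptors and ethynyl 0, but a single pair cannot show whether that difference has any bearing on the step.

Going by these compounds, whether an amine, a nitrile or a carboxylic acid on this aromatic carbon would return a measurable number remains open. Also open, on these data alone, is whether ethynyl in place of nitro would give a step of similar size with the 4-methyl-1,3-thiazol-2-yl amide of compound 2.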